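Hydrogen for chloro: from compound 2 to compound 3

The source may report more compounds than this note shows. Statements on the series, on what has been measured and on what is new or still open speak of the compounds shown alone.

Within the data shown here, compound 2 `COc1ccc(OC)c(/C=C/C(=O)N/N=C/c2ccc(Cl)cc2)c1` holds the lower of the two numbers so far in a functional assay on SF-295 cells (Homo sapiens) for antiproliferative activity, read by sulforhodamine B assay, with a stated time of 48 h (a lower number here means a stronger inhibitor of growth, a higher number a weaker inhibitor of growth), giving 6440 nM. Compound 1 `COc1ccc(OC)c(/C=C/c2nnc(Nc3ccc(Cl)cc3)o2)c1`, in this assay, gives 64500 nM, a gap beyond the scatter. Compound 3 `COc1ccc(OC)c(/C=C/C(=O)N/N=C/c2ccccc2)c1` is not yet measured; it differs from compound 2 by hydrogen in place of chloro on an aromatic carbon. Among the measured compounds shown here, no measured pair shows this change, so the size of the step is open; a small shift toward a higher number, at most barely beyond the scatter, is expected. For compound 3 the expected value in this assay is 9500 nM, between 3500 nM and 26000 nM. The expected step is a 1.5-fold higher number from compound 2 to compound 3 (0.17 log units; within the scatter).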

Compound 3, concentration for total growth inhibition: 11100 nM
For compound 3 the middle estimate is 1.2-fold (0.07 log units) below the measured one; measured number inside the range.
By their numbers in this assay, from the lowest: compounds 2 and 3 (each within the scatter of the next); then compound 1.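

In this assay, the change from 4-chlorophenyl to phenyl gives a 1.7-fold higher number from compound 2 to compound 3 (0.24 log units; within the scatter). Among these compounds, this is the first reading of this position, para to a large group, and it shows that the chloro can give way to hydrogen with no change beyond the scatter. In this pair, the chloro is therefore not required to hold the number in this range.

From the compounds shown here alone, whether an amine or a carboxylic acid at the same place would do the same remains open, as does the outcome of this change on the core of compound 1. The data shown offer no reason for this step.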